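This account rests on a few compounds, and the source may have more. Where it says the series, first, only, none or still open, it means among the compounds named here.

Measured in a functional assay on MDA-MB-231 cells (Homo sapiens) for inhibition, read by sulforhodamine B assay, tested at 10 uM; on this read-out lower numbers stand for less inhibition and higher numbers for more inhibition at the one concentration tested (going by the name of the read-out):
- compound 1 `CN1CCN(c2ccc(C3=NN(S(=O)(=O)C4CC4)C(c4ccc(N(C)C)cc4)C3)cc2)CC1`: 3.7%
- compound 2 `CN1CCN(c2ccc(C3=NN(S(=O)(=O)c4ccc(F)cc4)C(c4ccc(N(C)C)cc4)C3)cc2)CC1`: 15.7%
- compound 3 `CN1CCN(c2ccc(C3=NN(S(=O)(=O)c4ccc(Br)cc4)C(c4ccc(N(C)C)cc4)C3)cc2)CC1`: 23.7%

Compound 3 has the highest of the three numbers. Its nearest neighbour is compound 2, with a number 8 percentage points higher from compound 2 to compound 3 (within the scatter); the furthest is compound 1, with a number 20 percentage points higher from compound 1 to compound 3 (beyond the scatter). Compound 4 `CN1CCN(c2ccc(C3=NN(S(=O)(=O)c4ccc(OC(F)(F)F)cc4)C(c4ccc(N(C)C)cc4)C3)cc2)CC1` differs from compound 3 in one place: trifluoromethoxy in place of bromo on an aromatic carbon. The step that bears most directly on this is a number 8 percentage points higher from compound 2 to compound 3 (within the scatter), since it also swaps one group for another on the same aromatic carbon and stayed within the scatter. The larger steps, a number 12 percentage points higher from compound 1 to compound 2 (beyond the scatter) and a number 20 percentage points higher from compound 1 to compound 3 (beyond the scatter), came from exchanging the group on the sulfonyl sulfur, which compound 4 keeps. The expected step is therefore a number 1.7 percentage points lower from compound 3 to compound 4 (within the scatter), not beyond the scatter. Compound 4 is estimated at 22%, within 8% to 38%.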

Compound 4, a percentage reported as inhibition, at one concentration (the size of the read-out at that concentration, not a potency): 10.6%
Estimate against measurement, compound 4: 11.4 percentage points above; measured number inside the range.
By their numbers in this assay, from the lowest: compounds 1, 4, 2 and 3 (each within the scatter of the next, the first and the last beyond it).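

In this assay, going by these compounds alone, the group on this aromatic carbon can shift the number: trifluoromethoxy in place of bromo gives a number 13.1 percentage points lower from compound 3 to compound 4 (beyond the scatter), the first change on this carbon to go beyond the scatter. Against fluoro on the same carbon the step is a number 5.1 percentage points lower from compound 2 to compound 4 (within the scatter), and against cyclopropyl on the sulfonyl sulfur it is a number 6.9 percentage points higher from compound 1 to compound 4 (within the scatter), so the 4-(trifluoromethoxy)phenyl group cannot be told apart from either. Nothing measured here gives a reason for these steps.

Still open, from the compounds shown here alone, is how an amine or a carboxylic acid on this aromatic carbon would read, and how these compounds compare at other concentrations.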